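Two Sulfonamides Measured, a Naphthyl Analogue Still Open

A few compounds are considered here, and "the series" means these few. Any claim that something is new, unique, unknown or untested is made for them only; others in the source may bear on it.

Compound 1, `CC(C)Cc1cc(CNS(=O)(=O)Cc2cccc3ccccc23)nn1-c1ccccc1`: 28.7%
Compound 2, `CC(C)Cc1cc(CNS(=O)(=O)c2cccc(Cl)c2)nn1-c1ccccc1`: 40.8%

Both were tested in an assay on isolated protein for binding affinity to 5-hydroxytryptamine receptor 6 (Homo sapiens), tested at 10 uM; on this read-out higher numbers stand for more inhibition at the one concentration tested (going by the name of the read-out) and lower numbers for less inhibition. Compound 2 stands highest of the two numbers, and its gap to compound 1 lies beyond the usual scatter. Compound 3, `CC(C)Cc1cc(CNS(=O)(=O)c2cccc3ccccc23)nn1-c1ccccc1`, has not been measured. It differs from compound 2 in one place: naphthalen-1-yl in place of 3-chlorophenyl on a sulfonyl sulfur. Among the measured compounds shown here, with only two measured compounds, no step for this exact change is known. The step of a number 5.8 percentage points lower from compound 2 to compound 3 (within the scatter) is expected to be small, within the scatter, pointing slightly downward. Compound 3 is therefore estimated to give 35%, in a range from 15% to 55%.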

Compound 3, a percentage reported as inhibition, at one concentration (the size of the read-out at that concentration, not a potency): 77.7%
For compound 3 the middle estimate is 42.7 percentage points below the measured one; measured number above the stated range.
By their numbers in this assay, from the lowest: compound 1; then compound 2; then compound 3.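

On a sulfonyl sulfur, the choice of aromatic group can matter a great deal: in this assay, naphthalen-1-yl in place of 3-chlorophenyl gives a number 36.9 percentage points higher from compound 2 to compound 3 (beyond the scatter). Neither group carries hydrogen-bond donors or acceptors, so this large rise comes with a swap from one six-membered aromatic ring bearing chlorine to two of carbon only. Nothing available explains the rise.

The compounds shown leave open how plain phenyl or naphthalen-2-yl would read on this sulfur, and whether an amine on the naphthalene would keep the high reading.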